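The source may report more compounds than this note shows. Statements on the series, on what has been measured and on what is new or still open speak of the compounds shown alone.

Measured compounds in a functional assay on A549 cells (Homo sapiens) for cytotoxicity, read by MTT assay, with a stated time of 72 h; on this read-out higher numbers stand for weaker inhibition and lower numbers for stronger inhibition:
compound 1 `CC1CCN(Cc2ccc3nc(NC(=O)N/N=C/c4cn(Cc5ccc(Cl)cc5Cl)c5ccccc45)sc3c2)CC1` gives 3640 nM.
compound 2 `CC1CCN(Cc2ccc3nc(NC(=O)N/N=C/c4cn(Cc5cccc(Cl)c5)c5ccccc45)sc3c2)CC1` gives 2810 nM.
compound 3 `CN(C)Cc1ccc2nc(NC(=O)N/N=C/c3cn(Cc4cccc(Cl)c4)c4ccccc34)sc2c1` gives 1240 nM.

Compound 4 `CN(C)Cc1ccc2nc(NC(=O)N/N=C/c3cn(Cc4ccc(Cl)cc4Cl)c4ccccc34)sc2c1` is not yet measured in this assay.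

Two changes run through the set. The first sits on the benzyl group: 2,4-dichlorophenyl in place of 3-chlorophenyl on a saturated chain carbon bound to an aromatic nitrogen. Made once between measured compounds, it gave a 1.3-fold higher number from compound 2 to compound 1 (0.11 log units; within the scatter). The second sits on the core: dimethylamino in place of 4-methylpiperidin-1-yl on a saturated chain carbon bound to an aromatic carbon. It gave a 2.3-fold lower number from compound 2 to compound 3 (0.36 log units; beyond the scatter), and compound 3 thereby stands with the lowest number of the three measured, its steps to compound 2 and to compound 1 both beyond the scatter.

Compound 4 carries the core of compound 3 with the first change applied: 2,4-dichlorophenyl in place of 3-chlorophenyl on a saturated chain carbon bound to an aromatic nitrogen. The place of this change reads the same, word for word, as in the pair of compound 2 and compound 1, so it is the same change, only made on the core of compound 3 rather than on that of compound 2. One measured instance of it exists, and there it stayed within the scatter.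

The step from compound 3 to compound 4 is expected to be a 1.3-fold higher number from compound 3 to compound 4 (0.11 log units; within the scatter), that is, a small movement of no settled direction, because the one shown instance a 1.3-fold higher number from compound 2 to compound 1 (0.11 log units; within the scatter) lay within the scatter. Starting from compound 3 with 1240 nM, compound 4 is estimated at 1600 nM in this assay, with a range from 800 nM to 3300 nM.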

Compound 4, half-maximal inhibitory concentration: 2000 nM
Beside the measured number, compound 4's estimate is 1.3-fold (0.10 log units) below it; low and high end bracket the measured number.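

In this assay, the change from 3-chlorobenzyl to 2,4-dichlorobenzyl on the core of compound 3 gives a 1.6-fold higher number from compound 3 to compound 4 (0.21 log units; within the scatter), and the two instances of this change agree: the same change on two cores in this assay, a 1.3-fold higher number (0.11 log units; within the scatter) from compound 2 to compound 1 and a 1.6-fold higher number (0.21 log units; within the scatter) from compound 3 to compound 4, 1.2-fold (0.10 log units) apart, within the scatter of two such steps. Within the data shown here, replacing 4-methylpiperidin-1-yl with dimethylamino in the 2,4-dichlorobenzyl pair gives a 1.8-fold lower number from compound 1 to compound 4 (0.26 log units; within the scatter), and this change also carries over from one background to the other, although only one of its two steps lies beyond the scatter: the same change on two cores in this assay, a 2.3-fold lower number (0.36 log units; beyond the scatter) from compound 2 to compound 3 and a 1.8-fold lower number (0.26 log units; within the scatter) from compound 1 to compound 4, 1.2-fold (0.10 log units) apart, within the scatter of two such steps. Across these four compounds, each change therefore transfers without a detectable dependence on the other, but this rests on just two instances per change, and since neither benzyl step leaves the scatter, no direction is established for that change and nothing is shown beyond these compounds.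

As far as these compounds go, it remains open whether the same transfer holds for other amines on the core, such as morpholine or piperazine, or for a primary amine. Also open, from the compounds shown here alone, is how the benzyl position would read with an unsubstituted benzyl group, a methoxy-bearing benzyl group or a longer chain between the ring and the aromatic nitrogen.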